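Removing the ethyl branch from the amide linker

The source may report more compounds than this note shows. Statements on the series, on what has been measured and on what is new or still open speak of the compounds shown alone.

Two compounds of the series have numbers in a functional assay on the whole organism (strain Swiss) with Mus musculus as the target, in the maximal electroshock model, with a stated time of 0.5 h (on this read-out lower numbers stand for an effect already at smaller amounts and higher numbers for an effect only at larger amounts of compound), so far. Compound 1, `CCC(C(=O)N1CCN(c2cccc(C(F)(F)F)c2)CC1)N1C(=O)CC(C)C1=O`, gives 75.7 mg/kg in this assay. Compound 2, `CC1CC(=O)N(C(C)C(=O)N2CCN(c3cccc(Cl)c3)CC2)C1=O`, gives 98.5 mg/kg in this assay. Compound 1 has the lowest of the two numbers, but the gap to compound 2 is within the scatter, so the two values cannot be told apart.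

The next compound, compound 3, `CC1CC(=O)N(CC(=O)N2CCN(c3cccc(C(F)(F)F)c3)CC2)C1=O`, is not yet measured in this assay. It differs from compound 1 in one place: hydrogen in place of ethyl on a saturated chain carbon bound to an amide-type nitrogen in a ring and a carbonyl carbon. For the measured compounds named here, no measured pair shows the effect of this change, so no step size can be read off. The expectation is therefore a small step, most likely toward a higher number, and quite possibly none beyond the scatter, since compound 2 with a methyl at the same carbon gives 98.5 mg/kg.

For compound 3 the estimate in this assay is 115 mg/kg, with a range from 50 mg/kg to 260 mg/kg, which means an expected step of a 1.5-fold higher number from compound 1 to compound 3 (0.18 log units; within the scatter).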

Compound 3, dose for half-maximal effect: 80.6 mg/kg
Estimate against measurement, compound 3: 1.4-fold (0.15 log units) above; measured number inside the range.
By their numbers in this assay, from the lowest: compounds 1, 3 and 2 (each within the scatter of the next).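

In this assay the series now has its first readable step at this position, a 1.1-fold higher number from compound 1 to compound 3 (0.03 log units; within the scatter) for hydrogen in place of ethyl on a saturated chain carbon bound to an amide-type nitrogen in a ring and a carbonyl carbon. With the rest of the structure held constant, loss of the ethyl group and its 2 heavy atoms leaves no change that can be told from the scatter, so on this core the branch is not needed for a value in this dose range. Nothing available bears on why this position accepts the exchange.

The compounds shown leave open whether a longer chain, a phenyl ring, a hydroxyl group or an amine on this carbon would also stay within the scatter, since only hydrogen and ethyl can be compared directly on this core. Going by these compounds, compound 2 carries a methyl at this carbon but also differs in a second place, so it does not show the effect of the methyl alone, and whether the step would hold with other substituents on the shared core remains unknown.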